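The source may report more compounds than this note shows. Statements on the series, on what has been measured and on what is new or still open speak of the compounds shown alone.

Compound 1 `COc1cc(-c2cc(/C=C/C(=O)c3ccc(N)cc3)[nH]n2)cc(OC)c1OC` and compound 2 `COc1ccc(-c2cc(/C=C/C(=O)c3ccc(N)cc3)[nH]n2)cc1OC` are built on the same core and differ in a single place. In a functional assay on ACHN cells (Homo sapiens) for cytotoxicity, read by sulforhodamine B assay, with a stated time of 48 h, tested at 0.01 uM (on this read-out higher numbers stand for a weaker effect at the one concentration tested and lower numbers for a stronger effect), compound 1 gives 95%, and compound 2 gives 93%. The change between them is hydrogen in place of methoxy on an aromatic carbon, and it made the step of a number 2 percentage points lower from compound 1 to compound 2 (within the scatter). Compound 3 `COc1cc(C(=O)/C=C/c2cc(-c3cc(OC)c(OC)c(OC)c3)n[nH]2)cc(OC)c1OC` rests on a different core; in this assay compound 3 gives 103%. How the core of compound 3 differs from the core of compound 1 is not broken down here. Compound 4 `COc1ccc(-c2cc(/C=C/C(=O)c3cc(OC)c(OC)c(OC)c3)[nH]n2)cc1OC` has not yet been measured. It differs from compound 3 by hydrogen in place of methoxy on an aromatic carbon, the same change as that between compound 1 and compound 2, at a place described in the same words. The step of a number 2 percentage points lower from compound 3 to compound 4 (within the scatter) is expected, resting on the earlier step of a number 2 percentage points lower from compound 1 to compound 2 (within the scatter), which lay within the scatter. Compound 4 is therefore estimated at 101%, expected to fall between 91% and 111%.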

Compound 4, a percentage reported as activity, at one concentration (the size of the read-out at that concentration, not a potency): 95%
The estimate for compound 4 lay 6 percentage points above the measured number; the measured number falls inside the stated range.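

In this assay, putting hydrogen in place of methoxy on an aromatic carbon gave a number 8 percentage points lower from compound 3 to compound 4 (within the scatter). Set beside the earlier step, the change looks the same on both cores: the same change on two cores in this assay, a number 2 percentage points lower (within the scatter) from compound 1 to compound 2 and a number 8 percentage points lower (within the scatter) from compound 3 to compound 4, 6 percentage points apart, within the scatter of two such steps This shows only that neither core reveals an effect of the change that stands out from the scatter at this one concentration; it does not show that a clear effect would carry from one core to the other, as no such effect is seen here.

The compounds shown leave open what a different group at that aromatic carbon, such as a hydroxyl or a fluorine atom, would do. They also leave open whether the change matters at other concentrations.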